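The source may report more compounds than this note shows. Statements on the series, on what has been measured and on what is new or still open speak of the compounds shown alone.

Compound 1 `CC/C(=C(/c1ccc(/C=C/C(=O)O)cc1)c1ccc2[nH]c(=O)sc2c1)c1ccccc1` gives 158 nM
Compound 2 `CC/C(=C(/c1ccc(/C=C/C(=O)O)cc1)c1ccc2[nH]cnc2c1)c1ccccc1` gives 1180 nM

For the measured compounds named here, in a functional assay on MCF7 cells (Homo sapiens) for cytotoxicity, read by CellTiter-Glo, with a stated time of 5 days (a lower number here means a stronger inhibitor, a higher number a weaker inhibitor), compound 1 gives 158 nM as the lower of the two numbers so far. Compound 3 `CC/C(=C(/c1ccc(/C=C/C(=O)O)cc1)c1ccc2[nH]ncc2c1)c1ccccc1` is not yet measured. The difference from compound 1 is a group of 9 heavy atoms (7 carbon, 2 nitrogen; one five-membered aromatic ring with 2 hetero atoms, one six-membered aromatic ring of carbon only) in place of a group of 10 heavy atoms (7 carbon, 1 nitrogen, 1 oxygen, 1 sulfur; one five-membered aromatic ring with 2 hetero atoms, one six-membered aromatic ring of carbon only), on a double-bonded chain carbon bound to an aromatic carbon and a double-bonded chain carbon and it brings in 1H-indazol-5-yl. Going by the values given here, only one measured step bears on this: a 7.5-fold higher number from compound 1 to compound 2 (0.87 log units; beyond the scatter) and it replaces the same group with one of the same heavy-atom count as in compound 3. A higher number is therefore expected, but one step is thin evidence, so a smaller rise is assumed. The expected change is a 2.2-fold higher number from compound 1 to compound 3 (0.35 log units; beyond the scatter) (an estimate only). Compound 3 is estimated at 350 nM (range 80 nM to 1300 nM).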

Compound 3, half-maximal inhibitory concentration: 6 nM
Beside the measured number, compound 3's estimate is 58-fold (1.77 log units) above it, outside the stated range (below it).
By their numbers in this assay, from the lowest: compound 3; then compound 1; then compound 2.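

In this assay, placing 1H-indazol-5-yl on this double-bonded chain carbon gives a 26-fold lower number from compound 1 to compound 3 (1.42 log units; beyond the scatter), so replacing the original group can strongly lower the number as well as raise it. 1H-benzimidazol-5-yl is built from the same atoms, yet the change from it gives a 200-fold lower number from compound 2 to compound 3 (2.29 log units; beyond the scatter), so the arrangement of atoms within this group matters greatly here. Nothing available explains this difference.

On these data alone, it remains open whether 1H-indol-5-yl at this place would keep the number as low. Whether an amide could replace the carboxylic acid while the indazole stays is also unknown.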